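The source may hold more compounds than are shown below. What is called first, only, known or untested is meant among the compounds shown, and "the series" means these compounds.

Working notes on the series.

Compound 1 `C=CCOc1c(C)c(C)c2c(c1C)CCC(C)(COc1ccc(/C=C3\SC(=O)NC3=O)cc1Br)O2` is measured in a functional assay on MCF7 cells (Homo sapiens), tested at 5 uM (a higher number here means a weaker effect of the compound at the concentration tested, a lower number a stronger effect), and gives 98% there. Two further compounds share the core of compound 1 and have been run in the same setting. Compound 2 `Cc1c(C)c2c(c(C)c1OC(=O)CCC(=O)O)CCC(C)(COc1ccc(/C=C3\SC(=O)NC3=O)cc1)O2` gives 98% in this assay, the same figure as compound 1 at the digits shown. Compound 3 `C=CCOc1c(C)c(C)c2c(c1C)CCC(C)(COc1cccc(/C=C3\SC(=O)NC3=O)c1)O2` gives 92% in this assay; its gap to compound 1 lies within the usual scatter of repeated measurements, so no order can be read between the three. For the measured compounds named here, all three figures sit close to the top of the scale, which means a weak effect at the concentration tested throughout the set so far, and no two measured compounds differ in only one place, so no single step has been measured.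

Compound 4 `C=CCOc1c(C)c(C)c2c(c1C)CCC(C)(COc1ccc(/C=C3\SC(=O)NC3=O)cc1C)O2` has not been measured. Relative to compound 1 the change is methyl in place of bromo on an aromatic carbon, a one-for-one swap of a single heavy atom at the same aromatic carbon. With every measured compound of this core giving a figure near the top of the scale in this assay, the expected step of a number 2 percentage points lower from compound 1 to compound 4 (within the scatter) is none beyond the scatter. Compound 4 is therefore estimated at 96% in this assay, with a range from 85% to 104%; this expectation rests on compound 1 at 98% and compound 2 at 98%.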

Compound 4, a percentage reported as activity, at one concentration (the size of the read-out at that concentration, not a potency): 24%
Compound 4: middle estimate off by 72 percentage points, on the high side; measured number outside the range, below it.
By their numbers in this assay, from the lowest: compound 4; then compounds 3, 1 and 2 (each within the scatter of the next).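

For the compounds shown here, the swap of bromo for methyl on this aromatic carbon, ortho to a large group and meta to a group of 8 heavy atoms, gives the first single step: a number 74 percentage points lower from compound 1 to compound 4 (beyond the scatter) in this assay. A single position on the shared core can therefore separate a weak effect from a strong one at the concentration tested, even though the figures measured earlier gave no sign of this. The group that leaves and the group that enters match in heavy-atom count, hydrogen-bond donors, hydrogen-bond acceptors and net charge, so those counts do not distinguish them, and no measurement at hand accounts for the step.

On these data alone, it remains open whether the stronger effect is specific to methyl or also appears with hydrogen, chloro, ethyl, methoxy or an amine on the same carbon. As far as these compounds go, it is also open whether the methyl group would have a similar effect on the core of compound 2, which carries a carboxylic acid ester in place of the allyl ether.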